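This account rests on a few compounds, and the source may have more. Where it says the series, first, only, none or still open, it means among the compounds named here.

Measured compounds:
- compound 1 `O=C(N[C@H]1CCC[C@H](NC(=O)c2cnccn2)C1)c1cccc(Cl)c1`: in a functional assay on HEK293 cells for antagonist activity at metabotropic glutamate receptor 5 (Homo sapiens), read by FLIPR and calcium flux (on this read-out lower numbers stand for stronger inhibition and higher numbers for weaker inhibition), compound 1 gives 1370 nM.
- compound 2 `N#Cc1cccc(C(=O)N[C@@H]2CCC[C@H](NC(=O)c3ccccn3)C2)c1`: compound 2 is reported only as > 10000 nM, which is a limit of the assay and not a number.
- compound 3 `O=C(N[C@@H]1CCC[C@@H](NC(=O)c2ccccn2)C1)c1cccc(Cl)c1`: compound 3 gives 62 nM.

Of the two numbers in this assay, compound 1 holds the higher one; the gap to compound 3 lies well beyond the scatter, so compound 3 is the stronger inhibitor of the pair. Compound 2 contributes no number, as noted in the limit of > 10000 nM in this assay, at which 1 of the 3 values shown sits.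

Compound 4 `O=C(N[C@H]1CCC[C@H](NC(=O)c2cccc(Cl)c2)C1)c1cccnc1` differs from compound 1 by pyridin-3-yl in place of pyrazin-2-yl on a carbonyl carbon. Among the compounds with values here, no measured pair among the three compounds shows this exchange, so there is no step to lean on; compound 3 carries yet another ring on that carbonyl, and its value is all that can be said of it. The expectation for compound 4 is a step from compound 1 of no clear direction, most likely within the scatter or a mild weakening, a 1.5-fold higher number from compound 1 to compound 4 (0.16 log units; within the scatter). Compound 4 is therefore estimated at 2000 nM, with a range from 500 nM to 8000 nM.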

Compound 4, half-maximal inhibitory concentration: 612 nM
The estimate for compound 4 lay 3.3-fold (0.51 log units) above the measured number, within the range that was stated.
By their numbers in this assay, from the lowest: compound 3; then compound 4; then compound 1. At a limit, above all of these: compound 2.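

On a carbonyl carbon of the core of compound 1, in this assay, pyridin-3-yl in place of pyrazin-2-yl gives a 2.2-fold lower number from compound 1 to compound 4 (0.35 log units; beyond the scatter), the only exchange among these compounds that can be read as a change in one place. The ring on this carbonyl therefore affects the number, although this step is modest and rests on a single pair, so it gives a direction for this one exchange and no trend for the position. No measurement at hand gives a reason for the step.

Still open, on these data alone, is whether a plain phenyl ring, with no ring nitrogen, or a saturated ring such as piperidine on this carbonyl carbon would continue the step or reverse it. Also open, as far as these compounds go, is whether the same exchange would give a similar step on the core of compound 3.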